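The compounds below may be only part of what the source reports. "The series", "measured", "known", "first", "only" and "open" are said of these compounds alone.

Compound 1 `Cc1c(C=O)cc(-c2ccc(S(C)(=O)=O)cc2)n1-c1cccc(F)c1`: in a functional assay on the whole organism (strain Swiss albino) for inhibition, with Mus musculus as the target, in the writhing test, with a stated time of 30 min, at a dose of 10 mg/kg by the oral route (on this read-out higher numbers stand for a stronger effect at the one dose given and lower numbers for a weaker effect), compound 1 gives 39%.
Compound 2 `Cc1c(/C=N\O)cc(-c2ccc(S(C)(=O)=O)cc2)n1-c1ccc(F)cc1`: in this assay compound 2 gives 36%.

Compound 2 stands lowest of the two numbers, yet its nearest neighbour, compound 1, lies only a few points away, within the scatter, so neither compound can be called the stronger. Compound 3 `Cc1c(/C=N\O)cc(-c2ccc(S(C)(=O)=O)cc2)n1-c1cccc(F)c1` differs from compound 2 in one place: 3-fluorophenyl in place of 4-fluorophenyl on an aromatic nitrogen. Among the compounds with values here, no measured pair isolates this change, so nothing in the data points to a shift beyond the scatter in either direction. Compound 3 is therefore expected to show a step of a number 2 percentage points higher from compound 2 to compound 3 (within the scatter) in this assay, no larger than the scatter. The estimate for compound 3 is 38%, within a range from 25% to 52%.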

Compound 3, a percentage reported as inhibition, in the whole organism at one dose (the size of the read-out at that dose, not a potency): 32%
Estimate against measurement, compound 3: 6 percentage points above; measured number inside the range.
By their numbers in this assay, from the lowest: compounds 3, 2 and 1 (each within the scatter of the next).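

With 3-fluorophenyl in place of 4-fluorophenyl on the aromatic nitrogen, this assay gives a number 4 percentage points lower from compound 2 to compound 3 (within the scatter), so this shift of the fluorine leaves no readable mark at this position. The group of 3 heavy atoms in place of the group of 2 heavy atoms on the aromatic carbon gives a number 7 percentage points lower from compound 1 to compound 3 (within the scatter) and so also stays inside the usual spread. No measurement bears on the cause of either step. Open, on these data alone, is whether a plain phenyl or 4-chlorophenyl on the aromatic nitrogen, or a carboxylic acid or an amine on the aromatic carbon, would move the read-out beyond that spread.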